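The source may report more compounds than this note shows. Statements on the series, on what has been measured and on what is new or still open speak of the compounds shown alone.

Measured compounds:
compound 1, `CC[C@H]1C(=O)N=C(N)N1C(=O)OCc1ccccc1`: 69.2 mg/kg
compound 2, `CCCC[C@H]1C(=O)N=C(N)N1C(=O)OCc1ccccc1`: > 1000 mg/kg

Among the measured compounds shown here, in a functional assay on the whole organism with Mus musculus as the target, in the maximal electroshock model (a higher number here means that more compound is needed for the effect, a lower number that less compound is needed), compound 1 gives 69.2 mg/kg, and this is the only real number among the two values shown. Compound 2 does not give a number in this assay but only a limit, > 1000 mg/kg.

Compound 3, `CCC(C)[C@H]1C(=O)N=C(N)N1C(=O)OCc1ccccc1`, is not yet measured. It differs from compound 1 by ethyl in place of hydrogen on a saturated chain carbon bound to a saturated chain carbon and a saturated ring carbon. For the measured compounds named here, only one measured step bears on this change: an at least 14-fold higher number from compound 1 to compound 2 (1.15 log units; beyond the scatter), a step that ends at the limit of > 1000 mg/kg in this assay, at which 1 of the 2 values shown sits. That step also adds an ethyl to the chain on the ring carbon, there on a saturated chain carbon two bonds along the chain from the saturated ring carbon, whereas in compound 3 the ethyl enters on the carbon bound to the ring carbon. With a single comparison, and that one reaching only a limit, the size for the branched case cannot be fixed closely, but the direction is expected to be the same. On that basis the step expected in this assay is a 4.3-fold higher number from compound 1 to compound 3 (0.64 log units; beyond the scatter), an increase beyond the scatter. Compound 3 is therefore expected to give 300 mg/kg, within a range from 100 mg/kg to 1000 mg/kg.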

Compound 3, dose for half-maximal effect: 74.4 mg/kg
Compound 3: the middle estimate sits 4.0-fold (0.61 log units) above what was measured; measured number below the stated range.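

In this assay, ethyl in place of hydrogen on a saturated chain carbon bound to a saturated chain carbon and a saturated ring carbon leaves compound 3 within the scatter of compound 1 (a 1.1-fold higher number from compound 1 to compound 3 (0.03 log units; within the scatter)), so the sec-butyl group of compound 3 does not separate it from the ethyl group of compound 1 in this read-out. The same entering ethyl on a saturated chain carbon two bonds along the chain from a saturated ring carbon had given a large step (an at least 14-fold higher number from compound 1 to compound 2 (1.15 log units; beyond the scatter)), and the two compounds with the larger groups also stand far apart (an at least 13-fold lower number from compound 2 to compound 3 (1.12 log units; beyond the scatter)), so among these three compounds the place of the ethyl decides the outcome, and the added carbons alone do not. The last step is a bound and not a size, as its end at compound 2 is a limit: the limit of > 1000 mg/kg in this assay, at which 1 of the 3 values shown sits.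

The compounds shown leave open whether the result at this carbon extends to other branched groups such as isopropyl or tert-butyl, or to a larger one such as cyclohexyl. They also leave open how a hydroxyl or an amine on the same carbon would read in this assay.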